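Compound 4: (4-fluorophenyl)sulfonyl in Place of Methyl

The source may report more compounds than this note shows. Statements on the series, on what has been measured and on what is new or still open speak of the compounds shown alone.

Of the compounds shown here, three sharing one core have been measured in an ADME assay on L02 cells (Homo sapiens) for cytotoxicity, read by MTT assay, with a stated time of 24 h; a higher number here means a weaker inhibitor, a lower number a stronger inhibitor. Compound 1 (`CN1C/C(=C\c2cccnc2)C(=O)/C(=C/c2ccccc2F)C1`) gives 15900 nM. Compound 2 (`CN1C/C(=C\c2ccncc2)C(=O)/C(=C/c2ccccc2F)C1`) gives 14900 nM. Compound 3 (`CN1C/C(=C\c2ccncc2)C(=O)/C(=C/c2ccc(C#N)cc2)C1`) gives 14000 nM. Compound 2 therefore lies within the scatter of both other compounds, and the numbers set no order among the three.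

The next compound is compound 4 (`O=C1/C(=C/c2ccncc2)CN(S(=O)(=O)c2ccc(F)cc2)C/C1=C\c1ccccc1F`), which carries (4-fluorophenyl)sulfonyl in place of methyl on an amine nitrogen in a ring. Two measured steps offer indirect evidence: a 1.1-fold lower number from compound 1 to compound 2 (0.03 log units; within the scatter) and a 1.1-fold lower number from compound 2 to compound 3 (0.03 log units; within the scatter). Both lie within the scatter, but both concern a group on a double-bonded chain carbon bound to a double-bonded ring carbon. Going by the values given here, no measured pair varies the group on the amine nitrogen, so these steps can only weakly inform the new change.

On that thin evidence, no shift beyond the scatter is expected in this assay, and the direction remains uncertain. The expected change is a 1.4-fold lower number from compound 2 to compound 4 (0.13 log units; within the scatter), a slight lean rather than a firm call. For compound 4 the estimated value is 11000 nM, with an expected range from 3500 nM to 30000 nM.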

Compound 4, half-maximal inhibitory concentration: 15600 nM
Compound 4: middle estimate off by 1.4-fold (0.15 log units), on the low side, and the stated range covers the measured number.
By their numbers in this assay, from the lowest: compounds 3, 2, 4 and 1 (each within the scatter of the next).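

Going by these compounds alone, exchanging methyl for (4-fluorophenyl)sulfonyl on the amine nitrogen in a ring gives a 1.0-fold higher number from compound 2 to compound 4 (0.02 log units; within the scatter) in this assay, which is the first reading of any change at this position. The earlier compounds shown here varied only the groups on the double-bonded chain carbons, whereas this pair shows that the nitrogen can take a group of many more heavy atoms, with an aromatic ring and hydrogen-bond acceptors that methyl lacks, and the number still stays within the scatter. Nothing measured here accounts for this outcome.

The compounds shown leave open whether other groups on that nitrogen, such as a plain hydrogen, an acetyl or a benzyl group, or a phenylsulfonyl group without the fluorine, would also stay within the scatter. They also leave open whether the same exchange would read the same way on compound 3, which carries 4-cyanophenyl in place of 2-fluorophenyl, as this single pair tests it on one background only.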